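Adding a Chloro Group to Compound 2

This account rests on a few compounds, and the source may have more. Where it says the series, first, only, none or still open, it means among the compounds named here.

compound 1 `NS(=O)(=O)c1ccc(-n2nc(-c3ccc(Cl)cc3)cc2-c2cc(O)ccc2O)cc1`: 15100 nM
compound 2 `CC(=O)NS(=O)(=O)c1ccc(-n2nc(-c3ccccc3)cc2-c2cc(O)ccc2O)cc1`: 78600 nM

In a functional assay on cells (Cancer cell lines, Homo sapiens) for cytotoxicity, read by sulforhodamine B assay, with a stated time of 48 h (a higher number here means a weaker inhibitor of growth, a lower number a stronger inhibitor of growth), compound 1 gives 15100 nM, while compound 2 gives 78600 nM, the higher of the two numbers and beyond the scatter from compound 1. Compound 3 `CC(=O)NS(=O)(=O)c1ccc(-n2nc(-c3ccc(Cl)cc3)cc2-c2cc(O)ccc2O)cc1` has not yet been measured in this assay. It differs from compound 2 by chloro in place of hydrogen on an aromatic carbon. For the measured compounds named here, compound 1 and compound 2 differ in two places, so no single step between measured compounds is available; compound 1 shows only that a chloro-bearing analogue with another group elsewhere can sit lower. For compound 3 a modest downward step is expected, a 2.0-fold lower number from compound 2 to compound 3 (0.29 log units; within the scatter). Compound 3 is estimated at 40000 nM, within 12000 nM to 120000 nM.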

Compound 3, concentration for 50% growth inhibition: 37600 nM
For compound 3 the middle estimate is 1.1-fold (0.03 log units) above the measured one; the range from low to high includes it.
By their numbers in this assay, from the lowest: compound 1; then compound 3; then compound 2.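

In this assay, the phenyl to 4-chlorophenyl change now has a reading in one place: chloro in place of hydrogen, para to a large group, gives a 2.1-fold lower number from compound 2 to compound 3 (0.32 log units; beyond the scatter). Acetyl in place of hydrogen on the sulfonamide nitrogen can also now be read alone, with the 4-chlorophenyl group held constant, and it gives a 2.5-fold higher number from compound 1 to compound 3 (0.40 log units; beyond the scatter). The compounds shown leave open how fluoro, methoxy or an amine would compare with chloro at this place, and whether a longer acyl chain would compare with acetyl on the nitrogen. Nothing measured here accounts for either step.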